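The source may hold more compounds than are shown below. What is called first, only, known or untested is meant among the compounds shown, and "the series" means these compounds.

Measured in a functional assay on OVCAR-3 cells (Homo sapiens) for antiproliferative activity, read by MTT assay, with a stated time of 24 h; on this read-out lower numbers stand for stronger inhibition and higher numbers for weaker inhibition:
- Compound 1 `Cc1ccccc1NNC(=O)c1ccc(NS(=O)(=O)c2cnc(O)nc2O)cc1`: > 20000 nM (a limit)
- Compound 2 `CCCCOc1ccc(C(=O)NNC(=O)c2ccc(NS(=O)(=O)c3cnc(O)nc3O)cc2)cc1`: 12800 nM
- Compound 3 `Cc1ccccc1C(=O)NNC(=O)c1ccc(NS(=O)(=O)c2cnc(O)nc2O)cc1`: > 20000 nM (a limit)

Compound 3 has only a limit and no number, > 20000 nM. This is the limit of > 20000 nM in this assay, at which 2 of the 3 values shown sit.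

Compound 4 `O=C(NNC(=O)c1ccccc1Cl)c1ccc(NS(=O)(=O)c2cnc(O)nc2O)cc1` carries chloro in place of methyl on an aromatic carbon, ortho to a large group (chloro in place of methyl on an aromatic carbon).

Among the measured compounds shown here, two measured steps bear on this. One is an at least 1.5-fold higher number from compound 2 to compound 3 (0.19 log units; that floor lies within the scatter), where 2-methylphenyl replaces 4-butoxyphenyl on a carbonyl carbon. The other is a step that the two limits leave unreadable from compound 1 to compound 3. Neither exchanges methyl for chloro, and neither shows a readable change beyond the scatter.

The expected change is therefore small, with no direction favoured: a number no higher from compound 3 to compound 4 (the limit leaves the size open), estimated as none beyond the scatter.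

Compound 4 is estimated at 20000 nM, with an expected range from 11000 nM to 40000 nM.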

Compound 4, half-maximal inhibitory concentration: 5220 nM
Compound 4: middle estimate off by 3.8-fold (0.58 log units), on the high side; measured number outside the range, below it.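

In this assay, chloro on this aromatic carbon, ortho to a large group, gives the first step from the methyl compound that lies beyond the scatter: an at least 3.8-fold lower number from compound 3 to compound 4 (0.58 log units; beyond the scatter). Compound 4 also stands apart from the other two compounds, with a 2.5-fold lower number from compound 2 to compound 4 (0.39 log units; beyond the scatter) and an at least 3.8-fold lower number from compound 1 to compound 4 (0.58 log units; beyond the scatter). The true size of the methyl-to-chloro step stays open because compound 3 has only a limit: the limit of > 20000 nM in this assay, at which 2 of the 4 values shown sit.

The compounds shown leave open how fluoro, bromo or a nitrile on this same carbon would compare with chloro.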